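The source may hold more compounds than are shown below. What is called first, only, known or untested is meant among the compounds shown, and "the series" means these compounds.

Working notes on the amide series. Compound 1 `COC(=O)c1cccc(NC(=O)c2cc3cc([N+](=O)[O-])ccc3o2)c1` is the methoxycarbonyl member of the first core; in a physicochemical assay for solubility (a lower number here means a less soluble compound, a higher number a more soluble compound), compound 1 gives 25 ug/mL. Compound 3 `NC(=O)c1cccc(NC(=O)c2cc3cc([N+](=O)[O-])ccc3o2)c1` is the matching carbamoyl member, and in this assay compound 3 gives 20 ug/mL. The change from compound 1 to compound 3 is amino in place of methoxy on a carbonyl carbon. It made a step of a 1.3-fold lower number from compound 1 to compound 3 (0.10 log units; within the scatter), so these two numbers are not separated by this assay.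

Compound 2 `COC(=O)c1ccc(NC(=O)c2cc3ccccc3s2)cc1` belongs to a second core; the difference between the two cores is not broken down here. In this assay compound 2 gives 20 ug/mL. Against compound 3, compound 2 shows no change at the digits recorded, and against compound 1 the gap also stays within the scatter, so the three measured values sit together and no order among them can be read.

Compound 4 `NC(=O)c1ccc(NC(=O)c2cc3ccccc3s2)cc1` has not yet been measured. It differs from compound 2 by amino in place of methoxy on a carbonyl carbon, the same change as from compound 1 to compound 3, made at a place described in identical words. Within the data shown here, only one measured instance of this change exists, so the expectation rests on it alone: because a 1.3-fold lower number from compound 1 to compound 3 (0.10 log units; within the scatter) stayed within the scatter, the step is expected to be small again. For compound 4 the expected step is a 1.2-fold lower number from compound 2 to compound 4 (0.07 log units; within the scatter). Compound 4 is estimated at 17 ug/mL in this assay, with a range from 8 ug/mL to 35 ug/mL.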

Compound 4, solubility: 25 ug/mL
Compound 4: middle estimate off by 1.5-fold (0.17 log units), on the low side; measured number inside the range.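

In this assay the change of amino in place of methoxy on a carbonyl carbon now gives a 1.3-fold higher number from compound 2 to compound 4 (0.10 log units; within the scatter) and sits alongside a 1.3-fold lower number from compound 1 to compound 3 (0.10 log units; within the scatter) in the other core, so both steps lie within the scatter even though their printed directions differ. Among these compounds, this shows that, across these two cores, methoxycarbonyl to carbamoyl produced no step that this assay can separate from repeat variation, and the small size of the step carried from one core to the other; it does not show a direction for the change, and two instances do not establish that the step would stay small on any further core. No supporting measurement is available to explain the size of either step, so the result stands as an observation only.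

The compounds shown leave open whether a different group on the same carbonyl carbon, such as a carboxylic acid in place of methoxycarbonyl or dimethylamino in place of amino, would give a step beyond the scatter. They also leave open whether the same change stays this small on a core carrying an amine.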